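The source may report more compounds than this note shows. Statements on the series, on what has been measured and on what is new or still open speak of the compounds shown alone.

Compound 1 `O=C(O)c1ccn(Cc2cc(Br)ccc2OCc2ccccc2)n1` is the lower of the two numbers recorded in a functional assay on CHO-K1 cells for antagonist activity at prostaglandin E2 receptor EP1 subtype (Homo sapiens), read by FLIPR (on this read-out higher numbers stand for weaker inhibition and lower numbers for stronger inhibition), where compound 1 gives 55 nM. Among the measured compounds shown here, the only measured neighbor is compound 2 `CCCCc1cc(C(=O)O)nn1Cc1cc(Br)ccc1OCc1ccccc1`, which in this assay gives 977 nM; that step, an 18-fold higher number from compound 1 to compound 2 (1.25 log units; beyond the scatter), came from a butyl in place of hydrogen on an aromatic carbon of the shared core. Compound 3 `O=C(O)c1nn(Cc2cc(Br)ccc2OCc2ccccc2)cc1F` differs from compound 1 in another way: fluoro in place of hydrogen on an aromatic carbon. For the measured compounds named here, no measured step bears on this change directly; the one available step, an 18-fold higher number from compound 1 to compound 2 (1.25 log units; beyond the scatter), concerns a different group at a different ring carbon, so it gives only a loose guide. Since fluoro is far smaller than butyl, the step of a 1.5-fold higher number from compound 1 to compound 3 (0.16 log units; within the scatter) is expected to stay near or within the scatter. Compound 3 is therefore estimated at 80 nM in this assay, within a range of 30 nM to 250 nM.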

Compound 3, inhibition constant: 692 nM
Compound 3: the middle estimate sits 8.7-fold (0.94 log units) below what was measured, outside the stated range (above it).
By their numbers in this assay, from the lowest: compound 1; then compounds 3 and 2 (each within the scatter of the next).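

In this assay, a single fluoro on the aromatic carbon next to the ring atom that bears a carboxy group is enough for a large step, a 13-fold higher number from compound 1 to compound 3 (1.10 log units; beyond the scatter), although it brings only one heavy atom and no hydrogen-bond donor or acceptor. A large step on this ring is therefore not confined to the butyl of compound 2, whose step, an 18-fold higher number from compound 1 to compound 2 (1.25 log units; beyond the scatter), also lies beyond the scatter. No measurement is available here that accounts for the loss at this position.

The compounds shown leave open whether any replacement of this hydrogen gives a similar step, or whether a methyl, a chlorine or an amine on the same carbon would behave differently. They also leave open whether fluoro has the same effect when an amide stands in place of the carboxylic acid.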